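A few compounds are considered here, and "the series" means these few. Any claim that something is new, unique, unknown or untested is made for them only; others in the source may bear on it.

Of the compounds shown here, three sharing one core have been tested in an assay on isolated protein for inhibition of NUAK family SNF1-like kinase 1 (Homo sapiens), read by ADP-Glo, with a stated time of 60 min, tested at 10 uM, in the presence of a further agent that is not named here; a lower number here means less inhibition, a higher number more inhibition at the concentration tested (going by the name of the read-out). Compound 1 `CCC(=O)Nc1cccc(Oc2nc(Nc3ccc(N4CCCC4)cc3OC)ncc2Cl)c1` carries a methoxy group and a pyrrolidin-1-yl group; in this assay compound 1 gives 25.8%. Compound 2 `CCC(=O)Nc1cccc(Oc2nc(Nc3ccc(N(C)C)cc3)ncc2Cl)c1` lacks the methoxy group and carries a dimethylamino group in place of the ring; in this assay compound 2 gives 72.6%. Compound 3 `CCC(=O)Nc1cccc(Oc2nc(Nc3ccc(N4CCCC4)cc3)ncc2Cl)c1` keeps the pyrrolidin-1-yl group but lacks the methoxy group; in this assay compound 3 is reported as "not active" (no number reported), with no number given. Of the two numbers, compound 1 stands lowest, and its gap to compound 2 lies beyond the usual scatter.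

The next compound, compound 4 `CCC(=O)Nc1cccc(Oc2nc(Nc3ccc(N4CCCCC4)cc3OC)ncc2Cl)c1`, differs from compound 1 in one place: piperidin-1-yl in place of pyrrolidin-1-yl on an aromatic carbon. For the measured compounds named here, no pair of measured compounds shows what such a ring change does here, so there is little to build on. Compound 4 is expected to stay close to compound 1, with a step of a number 5.8 percentage points lower from compound 1 to compound 4 (within the scatter) that may well fall within the scatter. The estimated value of compound 4 in this assay is 20%, with a range from 5% to 40%.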

Compound 4, a percentage reported as inhibition, at one concentration (the size of the read-out at that concentration, not a potency): 13.9%
The estimate for compound 4 lay 6.1 percentage points above the measured number; the range from low to high includes it.
By their numbers in this assay, from the lowest: compound 4; then compound 1; then compound 2.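

For the compounds shown here, replacing pyrrolidin-1-yl with piperidin-1-yl on the aromatic carbon gives the only direct reading so far of a ring change at this place: in this assay ( the read-out at one concentration ) the swap gives a number 11.9 percentage points lower from compound 1 to compound 4 (beyond the scatter), a modest step that goes down rather than up. With the methoxy group present, then, the six-membered ring does not restore inhibition at this place, though one pair shows no general trend. No measurement at hand explains why the step goes this way.

As far as these compounds go, it remains open whether the same ring change would have a similar effect on a compound without the methoxy group. From the compounds shown here alone, it is also open how other rings at this place, such as morpholin-4-yl or 4-methylpiperazin-1-yl, would compare with the two rings seen here.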